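The source may report more compounds than this note shows. Statements on the series, on what has been measured and on what is new or still open speak of the compounds shown alone.

Of the compounds shown here, two sharing one core have so far been tested in an assay on HEK293 cells for negative allosteric modulation of metabotropic glutamate receptor 5 (Homo sapiens), read by FLIPR, with a stated time of 1 h; on this read-out higher numbers stand for weaker inhibition and lower numbers for stronger inhibition. Compound 1 `CN1CCc2nc(C#Cc3ccccc3)sc2C1` is the simpler of the pair; in this assay compound 1 gives > 10000 nM, which is a limit of the assay and not a number. Compound 2 `O=C(CC1CCOCC1)N1CCc2nc(C#Cc3ccccc3)sc2C1` carries an (oxan-4-yl)methyl amide on the core; in this assay compound 2 gives > 10000 nM, again a limit and not a number. Within the data shown here, compound 2 therefore stands exactly where every value so far stands, at the limit of > 10000 nM in this assay, at which 2 of the 2 values shown sit. Among the measured compounds shown here, no step between two measured compounds can be worked out here, since both values are limits rather than numbers.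

Compound 3 `O=C(N1CCCC1)N1CCc2nc(C#Cc3ccccc3)sc2C1` has not yet been measured. It differs from compound 2 by pyrrolidin-1-yl in place of (oxan-4-yl)methyl on a carbonyl carbon. For the measured compounds named here, with both known values sitting at the same limit, there is no measured step from which a direction could be read. The expectation for compound 3 is therefore no change beyond the usual scatter, with the step expected as a step that the limit leaves unreadable from compound 2 to compound 3. Compound 3 is estimated at 15000 nM, within a range from 4000 nM to 60000 nM, and most likely reported only as a limit once more.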

Compound 3, half-maximal inhibitory concentration: > 10000 nM
Compound 3 was reported as a limit (the forecaster's own chance of this, stated with the estimate: 80%); the middle value lies beyond the limit too.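

Compound 3 gives no readable step against compound 1 or compound 2, since all three compounds sit at the same limit, which is not a number: the limit of > 10000 nM in this assay, at which 3 of the 3 values shown sit.

The compounds shown leave open which change on the shared core, if any, would give a measurable value in this assay, and how the groups on the carbonyl carbon rank against one another.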